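Gastric stability of ester variants on a shared amide core

The compounds below may be only part of what the source reports. "The series", "measured", "known", "first", "only" and "open" are said of these compounds alone.

Measured so far:
compound 1 `CCOC(=O)/C=C/c1ccc(NC(=O)C2(NC(=O)c3ccc4c(C5CCCC5)c(-c5ncc(Cl)cn5)n(C)c4c3)CCC2)cc1OCC` — 0.333 h
compound 2 `CCOc1cc(NC(=O)C2(NC(=O)c3ccc4c(C5CCCC5)c(-c5ncc(Cl)cn5)n(C)c4c3)CCC2)ccc1/C=C/C(=O)OCC(C)C` — 1.43 h
compound 3 `CCOc1cc(NC(=O)C2(NC(=O)c3ccc4c(C5CCCC5)c(-c5ncc(Cl)cn5)n(C)c4c3)CCC2)ccc1/C=C/C(=O)OCc1ccccc1` — 1.83 h

The three measured compounds share one core and differ only in the group on the saturated chain carbon bound to an oxygen next to a carbonyl group. In an ADME assay on stomach for pharmacokinetics, in simulated gastric fluid (a lower number here means that the compound disappears faster, a higher number that the compound lasts longer), compound 3 gives the highest of the three numbers; compound 2 is nearest and within the scatter, compound 1 furthest and beyond it.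

Compound 4 `CCOc1cc(NC(=O)C2(NC(=O)c3ccc4c(C5CCCC5)c(-c5ncc(Cl)cn5)n(C)c4c3)CCC2)ccc1/C=C/C(=O)OCC(N)=O` has not yet been measured. It differs from compound 3 in one place: carbamoyl in place of phenyl on a saturated chain carbon bound to an oxygen next to a carbonyl group.

For the measured compounds named here, three measured steps concern this position. The two steps from compound 1, a 4.3-fold higher number from compound 1 to compound 2 (0.63 log units; beyond the scatter) and a 5.5-fold higher number from compound 1 to compound 3 (0.74 log units; beyond the scatter), were beyond the scatter; the step of a 1.3-fold higher number from compound 2 to compound 3 (0.11 log units; within the scatter) was within it. So a change here can move the number, but not every change does. Going by the values given here, no measured compound carries a carbamoyl at this place, so no step speaks directly to it. Compound 4 is expected to give a number in this assay somewhat below compound 3, a step of a 2.3-fold lower number from compound 3 to compound 4 (0.36 log units; beyond the scatter) of uncertain size that may stay within the scatter. The estimate for compound 4 is 0.8 h, with a range from 0.3 h to 2.2 h.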

Compound 4, half-life: 0.6 h
For compound 4 the middle estimate is 1.3-fold (0.12 log units) above the measured one; measured number inside the range.
By their numbers in this assay, from the lowest: compounds 1 and 4 (each within the scatter of the next); then compounds 2 and 3 (each within the scatter of the next).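

In this assay, a group other than methyl at this place does not by itself raise the number: carbamoyl falls away from the two higher compounds, phenyl (a 3.1-fold lower number from compound 3 to compound 4 (0.48 log units; beyond the scatter)) and isopropyl (a 2.4-fold lower number from compound 2 to compound 4 (0.38 log units; beyond the scatter)). Against methyl, carbamoyl stays within the scatter (a 1.8-fold higher number from compound 1 to compound 4 (0.26 log units; within the scatter)), so the gain seen on going from methyl to isopropyl or phenyl does not extend to every replacement. The four compounds now fall into two groups, with methyl and carbamoyl at the lower end and isopropyl and phenyl at the upper end, and each pair lies within the scatter of itself.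

Still open, going by these compounds, is whether a methylcarbamoyl or dimethylcarbamoyl group, which would alter the amide hydrogens of carbamoyl, would read with the lower pair or the upper pair, and whether a longer carbon chain or a cyclohexyl at this place would extend the upper group. Nothing available explains why carbamoyl and methyl read alike or why both differ from phenyl and isopropyl.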